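A few compounds are considered here, and "the series" means these few. Any claim that something is new, unique, unknown or untested is made for them only; others in the source may bear on it.

Of the compounds shown here, three sharing one core have been measured in an assay on CHO cells with metabotropic glutamate receptor 5 (Homo sapiens) as the target; on this read-out higher numbers stand for an effect only at larger amounts of compound and lower numbers for an effect already at smaller amounts. Compound 1 `Cc1ccc(C(=O)Nc2cc(-c3ccccc3)nn2-c2ccccc2)cc1` gives 30 nM in this assay. Compound 2 `O=C(Nc1cc(-c2ccccc2)nn1-c1ccccc1)c1cnccn1` gives 200 nM, and compound 3 `O=C(Nc1cc(-c2ccccc2)nn1-c1ccccc1)c1ccc(F)cc1` gives 30 nM. The step of a 6.7-fold higher number from compound 1 to compound 2 (0.82 log units; beyond the scatter) comes with pyrazin-2-yl in place of 4-methylphenyl on the carbonyl carbon, while the step of no change at the digits printed from compound 1 to compound 3 (within the scatter) comes with fluoro in place of methyl on an aromatic carbon. Compound 3 therefore stands level with compound 1 at the digits shown, the two together at the lower end of the three numbers, and compound 2 is the one furthest from it.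

Among the compounds with values here, compound 4 `O=C(Nc1cc(-c2ccccc2)nn1-c1ccccc1)c1ccc(C(F)(F)F)cc1` differs from compound 3 in one place: trifluoromethyl in place of fluoro on an aromatic carbon The only measured step that touches the same aromatic carbon is no change at the digits printed from compound 1 to compound 3 (within the scatter), and it lay within the scatter. Within the data shown here, no measured step introduces trifluoromethyl, so nothing here tells how that group behaves; the one related step suggests that a swap at this position moves the number little. For compound 4 the step of no change at the digits printed from compound 3 to compound 4 (within the scatter) is expected to stay within the scatter. The value of compound 4 is estimated at 30 nM, with a range from 10 nM to 90 nM.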

Compound 4, half-maximal effective concentration: 19 nM
Compound 4: the middle estimate sits 1.6-fold (0.20 log units) above what was measured; the measured number falls inside the stated range.
By their numbers in this assay, from the lowest: compounds 4, 1 and 3 (each within the scatter of the next); then compound 2.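

At this position, on an aromatic carbon para to a large group, trifluoromethyl brings 4 heavy atoms where fluoro has 1, yet the number barely moves: a 1.6-fold lower number from compound 3 to compound 4 (0.20 log units; within the scatter) and a 1.6-fold lower number from compound 1 to compound 4 (0.20 log units; within the scatter) both lie within the scatter in this assay. The three groups tried here, methyl, fluoro and trifluoromethyl, thus cannot be told apart on this read-out, and the larger group shows that added size at this spot need not raise the number, while the clear gap remains the one that comes with changing the ring itself, as in an 11-fold lower number from compound 2 to compound 4 (1.02 log units; beyond the scatter). Nothing available explains why these numbers fall as they do.

The compounds shown leave open what an amine, a carboxylic acid or a longer alkyl chain would do at this same position. They also leave open whether a ring other than pyrazin-2-yl that carries nitrogen, such as pyridin-3-yl, would give a number close to that of compound 2, which stands at 200 nM, or one closer to the phenyl compounds.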